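The source may hold more compounds than are shown below. What is called first, only, known or untested is meant among the compounds shown, and "the series" means these compounds.

Compound 1 `Cc1ccccc1-c1nn(-c2ccc(C(F)(F)F)cc2)cc1CNCCN1CCN(C)CC1` was measured in an ADME assay on Huh-7 cells (Homo sapiens) for cytotoxicity (a higher number here means that more compound is tolerated, a lower number that less compound is tolerated), and gave 11000 nM.
Compound 2 `Cc1ccccc1-c1nn(-c2ccc(F)cc2F)cc1CNCCN1CCCCC1` gave only a limit of this assay, > 20000 nM.
Compound 3 `CN1CCN(CCNCc2cn(-c3ccc(F)cc3F)nc2Cc2ccccc2)CC1` likewise gave only a limit of this assay, > 20000 nM.

On the numbers shown, compound 2 stands at the limit of > 20000 nM in this assay, at which 2 of the 3 values shown sit. For the measured compounds named here, a numerical reading exists only for compound 1, and the value of compound 2 is a limit, so no step between measured compounds can be stated.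

Compound 4 `CCCN1CCC(CNCc2cn(-c3ccc(F)cc3F)nc2-c2ccccc2C)CC1` has not yet been measured in this assay. It differs from compound 2 as follows: 1-propylpiperidin-4-yl in place of (piperidin-1-yl)methyl on a saturated chain carbon bound to an amine nitrogen. Going by the values given here, no measured pair shows the effect of this change, so the account rests on the position of compound 2 alone. A change of this kind is expected to move tolerance by no more than the usual scatter, in either direction. Compound 4 is therefore expected to give about 18000 nM in this assay, with a range from 8000 nM to 40000 nM. The step that this estimate implies is an at least 1.1-fold lower number from compound 2 to compound 4 (0.04 log units; that floor lies within the scatter), and it is an expectation only.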

Compound 4, half-maximal cytotoxic concentration: > 20000 nM
Compound 4: a limit, no number; the forecaster's own chance of this, stated with the estimate: 55%; middle value at least 1.1-fold (0.04 log units) away from the limit.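

For the compounds shown here, compound 2 and compound 4 each give only a limit in this assay, not a number, and no step between them can be read. The compounds shown leave open whether 1-propylpiperidin-4-yl in place of (piperidin-1-yl)methyl changes tolerance at all, and how far either compound lies past its limit.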